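Sulfonamide variation on a shared benzoxazole-free core: compound 4

This account rests on a few compounds, and the source may have more. Where it says the series, first, only, none or still open, it means among the compounds named here.

Compound 1 `Cc1ccc(S(=O)(=O)Nc2ccc3oc(-c4ccccc4)nc3c2)cc1` in an assay on cells for inhibition of HSP60/HSP10 (Homo sapiens), with a stated time of 60 min (a lower number here means a stronger inhibitor, a higher number a weaker inhibitor), reaches only the limit > 100000 nM.
Compound 2 `C=Cc1ccc(S(=O)(=O)Nc2ccc3oc(-c4ccccc4)nc3c2)cc1` in this assay likewise reaches only the limit > 100000 nM.
Compound 3 `O=S(=O)(Nc1ccc2oc(-c3ccccc3)nc2c1)c1cccs1` in this assay gives 90000 nM.

Compound 3 is the only one of the three with a number; the other two sit at the limit of > 100000 nM in this assay, at which 2 of the 3 values shown sit. Against that background, the step from compound 1 to compound 3 is an at least 1.1-fold lower number from compound 1 to compound 3 (0.04 log units; that floor lies within the scatter), and the step from compound 2 to compound 3 is an at least 1.1-fold lower number from compound 2 to compound 3 (0.04 log units; that floor lies within the scatter); neither floor reaches beyond the scatter. The step from compound 1 to compound 2 is a step that the two limits leave unreadable from compound 1 to compound 2.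

Compound 4 `O=S(=O)(Nc1ccc2oc(-c3ccccc3)nc2c1)c1ccccc1O` has not been measured. It differs from compound 3 as follows: 2-hydroxyphenyl in place of thiophen-2-yl on a sulfonyl sulfur. The two measured steps that change the group on the sulfonyl sulfur, both ending at compound 3, are the ones that bear on this; both give only a weak floor. The data therefore give no reason to expect a step beyond the scatter in this assay in either direction, and a fair chance that compound 4 returns only a limit.

Compound 4 is expected to give about 100000 nM in this assay, with a range from 30000 nM to 300000 nM. The expected step from compound 3 to compound 4 is therefore a 1.1-fold higher number from compound 3 to compound 4 (0.05 log units; within the scatter).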

Compound 4, half-maximal inhibitory concentration: 85000 nM
Compound 4: the middle estimate sits 1.2-fold (0.07 log units) above what was measured, within the range that was stated.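

In this assay, the change on the sulfonyl sulfur gives a 1.1-fold lower number from compound 3 to compound 4 (0.02 log units; within the scatter), so a six-membered aromatic ring of carbon only, carrying a hydroxyl group and with it a hydrogen-bond donor that thiophen-2-yl lacks, reads the same as the five-membered sulfur-containing ring within the scatter. Compared with the 4-vinylphenyl and 4-methylphenyl groups at this position, the readings are an at least 1.1-fold lower number from compound 2 to compound 4 (0.07 log units; that floor lies within the scatter) and an at least 1.1-fold lower number from compound 1 to compound 4 (0.07 log units; that floor lies within the scatter), and these floors add no step beyond the scatter to those already seen for compound 3. Compound 4 does give this position a second measured number, while the other two compounds remain at a limit: the limit of > 100000 nM in this assay, at which 2 of the 4 values shown sit.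

Whether any group on the sulfonyl sulfur can move the number beyond the scatter stays open, since all the groups shown are aromatic rings and none carries an amine or a carboxylic acid. Going by these compounds, it also remains unknown how a methoxy group in place of the hydroxyl, or an alkyl chain in place of the ring on the sulfonyl sulfur, would read in this assay.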